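Cytotoxicity in MT4 cells: allyl versus halogen on the core

The source may hold more compounds than are shown below. What is called first, only, known or untested is meant among the compounds shown, and "the series" means these compounds.

Measured compounds:
compound 1 `C=CCC1=C(N)[C@@]2(OS1(=O)=O)[C@@H](CO[Si](C)(C)C(C)(C)C)O[C@@H](n1cc(C)c(=O)n(C)c1=O)[C@@H]2O[Si](C)(C)C(C)(C)C`: 82000 nM
compound 2 `Cc1cn([C@@H]2O[C@H](CO[Si](C)(C)C(C)(C)C)[C@@]3(OS(=O)(=O)C(Br)=C3N)[C@H]2O[Si](C)(C)C(C)(C)C)c(=O)[nH]c1=O`: 18000 nM

In a functional assay on MT4 cells (Homo sapiens) for cytotoxicity (a higher number here means that more compound is tolerated, a lower number that less compound is tolerated), compound 1 gives the higher of the two numbers. Compound 2 gives a lower value, and the gap lies beyond the scatter. For the measured compounds named here, no pair with a single change has been measured.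

Compound 3 `Cc1cn([C@@H]2O[C@H](CO[Si](C)(C)C(C)(C)C)[C@@]3(OS(=O)(=O)C(I)=C3N)[C@H]2O[Si](C)(C)C(C)(C)C)c(=O)n(C)c1=O` is unmeasured. It differs from compound 1 as iodo in place of allyl on a double-bonded ring carbon.

Nothing pins down the size of this step, but compound 2, the only halogenated analog, sits lower than compound 1. In this assay compound 2 gives 18000 nM. The step from compound 1 to compound 3 is therefore expected to be downward, modest, near the edge of the scatter: a 2.3-fold lower number from compound 1 to compound 3 (0.37 log units; beyond the scatter). For compound 3 the estimate is 35000 nM, with a range from 12000 nM to 90000 nM.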

Compound 3, half-maximal cytotoxic concentration: 3900 nM
Estimate against measurement, compound 3: 9.0-fold (0.95 log units) above, and the stated range ends above it.
By their numbers in this assay, from the lowest: compound 3; then compound 2; then compound 1.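

With the rest of compound 1 unchanged, replacing allyl with iodo on the double-bonded ring carbon next to the ring sulfur gives a 21-fold lower number from compound 1 to compound 3 (1.32 log units; beyond the scatter) in this assay. For the compounds shown here, this is the first single-change reading, and it shows that tolerance in MT4 cells depends strongly on the group at this position. No available evidence bears on the origin of this step.

A methyl group or a propyl chain on this carbon would help show whether the step tracks the loss of allyl or the arrival of iodo.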